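This account rests on a few compounds, and the source may have more. Where it says the series, first, only, none or still open, it means among the compounds named here.

Measured so far: compound 1 `OC[C@H]1O[C@@H](n2cnc3c(OCc4ccccc4)ncnc32)[C@H](O)[C@@H]1O` gives 2090 nM in an assay on isolated protein for binding affinity to Equilibrative nucleoside transporter 1 (Homo sapiens); on this read-out lower numbers stand for stronger inhibition and higher numbers for weaker inhibition; compound 2 `OC[C@H]1O[C@@H](n2cnc3c(SCC4CCCCC4)ncnc32)[C@H](O)[C@@H]1O` gives 1550 nM; compound 3 `CC(C)(Sc1ncnc2c1ncn2[C@@H]1O[C@H](CO)[C@@H](O)[C@H]1O)c1ccccc1` gives 21400 nM.

Compound 2 has the lowest of the three numbers, though compound 1 lies within the scatter of it. Compound 4 `O=[N+]([O-])c1ccc(O)c(CSc2ncnc3c2ncn3[C@@H]2O[C@H](CO)[C@@H](O)[C@H]2O)c1` differs from compound 2 by 2-hydroxy-5-nitrophenyl in place of cyclohexyl on a saturated chain carbon bound to a sulfur. Going by the values given here, two steps bear on this. The step of a 1.3-fold lower number from compound 1 to compound 2 (0.13 log units; within the scatter) shows that exchanging a benzyloxy for a saturated ring on a sulfur-linked methylene hardly moved the number. The step of a 14-fold higher number from compound 2 to compound 3 (1.14 log units; beyond the scatter) shows a large loss, but there the chain carbon itself was altered, which compound 4 keeps. An aromatic ring on the unchanged chain carbon is therefore expected to give a step of a 1.3-fold lower number from compound 2 to compound 4 (0.11 log units; within the scatter), not beyond the scatter. Compound 4 is estimated at 1200 nM, in the range 250 nM to 6000 nM.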

Compound 4, half-maximal inhibitory concentration: 33.1 nM
For compound 4 the middle estimate is 36-fold (1.56 log units) above the measured one; the whole stated range lies above it.
By their numbers in this assay, from the lowest: compound 4; then compounds 2 and 1 (each within the scatter of the next); then compound 3.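

In this assay, 2-hydroxy-5-nitrophenyl in place of cyclohexyl on a saturated chain carbon bound to a sulfur gave a 47-fold lower number from compound 2 to compound 4 (1.67 log units; beyond the scatter), so the group carried there can matter greatly. The earlier step, a 1.3-fold lower number from compound 1 to compound 2 (0.13 log units; within the scatter), had not revealed this sensitivity. No available evidence accounts for the gain.

Compound 4 introduces the aromatic ring, hydroxy and nitro groups together, leaving the share of each unresolved. On these data alone, whether an amine or a carboxylic acid in place of the nitro group would preserve the low number also remains open.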